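Series notes: from compound 3 to compound 4

A few compounds are considered here, and "the series" means these few. Any claim that something is new, unique, unknown or untested is made for them only; others in the source may bear on it.

In a functional assay on MCF7 cells (Homo sapiens) for cytotoxicity, read by MTT assay, with a stated time of 3 days (on this read-out higher numbers stand for weaker inhibition and lower numbers for stronger inhibition), compound 3 `C[C@H]1O[C@@H](n2cc(F)c(NC(=O)Oc3ccc([N+](=O)[O-])cc3)nc2=O)[C@@H]2OC(=O)O[C@@H]21` gives 6 ug/mL, the lowest of the three numbers, against compound 2 `CCCCCOC(=O)Nc1nc(=O)n([C@@H]2O[C@H](C)[C@H]3OC(=O)O[C@H]32)cc1F` at 80 ug/mL and compound 1 `C[C@H]1O[C@@H](n2cc(F)c(NC(=O)Oc3ccc(Cl)cc3)nc2=O)[C@H](O)[C@@H]1O` at 100 ug/mL. Compound 4 `C[C@H]1O[C@@H](n2cc(F)c(NC(=O)Oc3ccc([N+](=O)[O-])cc3)nc2=O)[C@H](O)[C@@H]1O` keeps the 4-nitrophenyl group of compound 3 but carries 3,4-dihydroxy-5-methyloxolan-2-yl on the aromatic nitrogen: a group of 8 heavy atoms (5 carbon, 3 oxygen; one five-membered non-aromatic ring with 1 hetero atom) in place of a group of 10 heavy atoms (6 carbon, 4 oxygen; one five-membered non-aromatic ring with 1 hetero atom, one five-membered non-aromatic ring with 2 hetero atoms), on an aromatic nitrogen. For the measured compounds named here, the one measured step, a 13-fold lower number from compound 2 to compound 3 (1.12 log units; beyond the scatter), is large but lies at another place, so it bears only indirectly. The nearest guide is compound 1, which carries the same entering group and gives 100 ug/mL. A moderate rise in this assay is therefore expected, a 3.3-fold higher number from compound 3 to compound 4 (0.52 log units; beyond the scatter). For compound 4 the estimated value is 20 ug/mL, with an expected range of 6 ug/mL to 70 ug/mL.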

Compound 4, half-maximal inhibitory concentration: 180 ug/mL
The estimate for compound 4 lay 9.0-fold (0.95 log units) below the measured number; the whole stated range lies below it.
By their numbers in this assay, from the lowest: compound 3; then compounds 2, 1 and 4 (each within the scatter of the next, the first and the last beyond it).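

In this assay the group on the aromatic nitrogen matters strongly: with the 4-nitrophenyl group held constant, 3,4-dihydroxy-5-methyloxolan-2-yl gives a 30-fold higher number from compound 3 to compound 4 (1.48 log units; beyond the scatter) in this comparison. With that group in place, nitro in place of chloro gives only a 1.8-fold higher number from compound 1 to compound 4 (0.26 log units; within the scatter) here, so this change does not separate the two compounds. No available evidence accounts for the large step at the aromatic nitrogen.

Still open, on these data alone, is whether the group in compound 3 would keep its low number with chloro in place of nitro. Also open, as far as these compounds go, is how an amine on that aromatic carbon would read with either nitrogen group.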